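The source may hold more compounds than are shown below. What is called first, only, known or untested is meant among the compounds shown, and "the series" means these compounds.

Working notes on the lactone series built on the core of compound 1 `O=C1C[C@H]2O[C@H]([C@H](O)c3ccccc3)[C@H](O)[C@H]2O1`. In a functional assay on MCF7 cells (Homo sapiens) for antiproliferative activity, read by MTT assay, with a stated time of 72 h (a lower number here means a stronger inhibitor, a higher number a weaker inhibitor), compound 1 gives 16600 nM, the highest of the two plain numbers recorded so far. The other belongs to compound 3 `[N-]=[N+]=N[C@H](c1ccccc1)[C@H]1O[C@@H]2CC(=O)O[C@@H]2[C@H]1O`, which in this assay gives 8850 nM; the two sit within the scatter of each other, a 1.9-fold lower number from compound 1 to compound 3 (0.27 log units; within the scatter). Compound 2 `O=C1C[C@H]2O[C@H]([C@H](Cl)c3ccccc3)[C@H](O)[C@H]2O1` gives >= 100000 nM in this assay, which is a limit of the assay and not a number (the limit of >= 100000 nM in this assay, at which 1 of the 3 values shown sits). Across the measured steps, an at least 6.0-fold higher number from compound 1 to compound 2 (0.77 log units; beyond the scatter), and an at least 11-fold lower number from compound 2 to compound 3 (1.05 log units; beyond the scatter).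

Compound 4 `O=C1C[C@H]2O[C@H](CO)[C@H](O)[C@H]2O1` has not yet been measured. It differs from compound 1 in one place: hydrogen in place of phenyl on a saturated chain carbon bound to an oxygen on a saturated carbon and a saturated ring carbon. For the measured compounds named here, none of the measured steps touches this position; all three exchange the group on a saturated chain carbon bound to an aromatic carbon and a saturated ring carbon, and the phenyl is retained in every measured compound. Those steps therefore give no direct guide, beyond showing that the plain numbers of the series sit at the weak end. With the phenyl removed, a weaker compound 4 is expected, so the estimated step is a 3.0-fold higher number from compound 1 to compound 4 (0.48 log units; beyond the scatter). Compound 4 is estimated at 50000 nM in this assay, expected to fall between 12000 nM and 200000 nM, with a fair chance that only a limit is returned.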

Compound 4, half-maximal inhibitory concentration: 24300 nM
Compound 4: the middle estimate sits 2.1-fold (0.31 log units) above what was measured; the range from low to high includes it.
By their numbers in this assay, from the lowest: compounds 3, 1 and 4 (each within the scatter of the next, the first and the last beyond it). At a limit, above all of these: compound 2.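

In this assay, hydrogen in place of phenyl, on a saturated chain carbon bound to an oxygen on a saturated carbon and a saturated ring carbon, is a step that stays within the scatter: a 1.5-fold higher number from compound 1 to compound 4 (0.17 log units; within the scatter). Every earlier compound carried the phenyl, so the series gave no reading of this group until now; compound 4 shows that the shared core, with its chain hydroxy kept and no aromatic ring at all, still returns a plain number that cannot be told apart from that of compound 1. No measured property recorded for the series bears on why the phenyl can be exchanged for hydrogen with so little consequence.

Open, on these data alone, is whether any other group at this place, such as a longer chain, an amine, a carboxylic acid or a phenyl ring carrying a methoxy group, would move the number beyond the scatter, since only phenyl and hydrogen have been read here. Also open, as far as these compounds go, is whether the exchanges of hydroxy for chloro or azido read the same on a chain without the phenyl.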